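From 2-methylphenyl to 4-cyanophenyl in the series

The source may hold more compounds than are shown below. What is called first, only, known or untested is meant among the compounds shown, and "the series" means these compounds.

In an ADME assay on HUVEC cells (Homo sapiens) for inhibition, read by CCK-8 assay, with a stated time of 24 h, in the presence of a further agent that is not named here (on this read-out higher numbers stand for weaker inhibition and lower numbers for stronger inhibition), compound 1 `Cc1cccc(-n2cc(-c3ccc(/C=C4\C(=O)Nc5ccccc54)cc3)nn2)c1` gives 13700 nM. Compound 3 `Cc1ccccc1-n1cc(-c2ccc(C=C3C(=O)Nc4ccc(F)cc43)cc2)nn1` gives 8630 nM, which lies within the scatter of compound 1, so these two numbers cannot be ordered. Compound 2 `N#Cc1ccc(-n2cc(-c3ccc(C=C4C(=O)Nc5ccccc54)cc3)nn2)cc1`, which carries a 4-cyanophenyl, reads > 20000 nM, and this is a limit of the assay, not a number. Compound 4 `N#Cc1ccc(-n2cc(-c3ccc(C=C4C(=O)Nc5ccc(F)cc54)cc3)nn2)cc1` has 4-cyanophenyl in place of 2-methylphenyl on an aromatic nitrogen of compound 3 (4-cyanophenyl in place of 2-methylphenyl on an aromatic nitrogen). Going by the values given here, no measured step isolates this change, so the expectation is only a modest move towards a higher number in this assay, resting on the limit seen for compound 2. The expected step is a 1.7-fold higher number from compound 3 to compound 4 (0.24 log units; within the scatter). For compound 4 the estimated value is 15000 nM, with an expected range of 7000 nM to 30000 nM.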

Compound 4, half-maximal inhibitory concentration: > 20000 nM
Compound 4 ended at the assay's limit; the forecaster's own chance of this, stated with the estimate: 35%; middle value at least 1.3-fold (0.12 log units) from the limit.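

In this assay, going by these compounds alone, 4-cyanophenyl in place of 2-methylphenyl on an aromatic nitrogen gives an at least 2.3-fold higher number from compound 3 to compound 4 (0.36 log units; beyond the scatter) in the fluoro-bearing pair, the first direct reading of this change. The value of compound 4 is a limit of the assay, not a number, and compound 2, also with 4-cyanophenyl, ends at the same limit: the limit of > 20000 nM in this assay, at which 2 of the 4 values shown sit. With limits at both ends, the step for fluoro in place of hydrogen between compound 2 and compound 4 cannot be read.

As far as these compounds go, how far the 4-cyanophenyl compounds lie past that limit stays open. So does the reading of a 4-aminophenyl or 4-carboxyphenyl group on this aromatic nitrogen.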